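Shifting the Methoxy Group and Unmasking a Hydroxyl

A few compounds are considered here, and "the series" means these few. Any claim that something is new, unique, unknown or untested is made for them only; others in the source may bear on it.

Three compounds share a common core and differ only in the substituent on one aromatic carbon. Compound 1 `COc1ccc(-c2cc(-c3ccccc3-c3ccccc3)n[nH]2)cc1` carries a 4-methoxyphenyl, and in a functional assay on OVCAR cells (Homo sapiens) for inhibition, read by MTT assay, with a stated time of 48 h (a lower number here means a stronger inhibitor of growth, a higher number a weaker inhibitor of growth), compound 1 gives 670 nM. Compound 2 `COc1ccccc1-c1cc(-c2ccccc2-c2ccccc2)n[nH]1`, with a 2-methoxyphenyl, gives 14200 nM. Compound 3 `COc1cccc(-c2cc(-c3ccccc3-c3ccccc3)n[nH]2)c1`, bearing a 3-methoxyphenyl, gives 5800 nM; it stands second highest of the three numbers, closer to compound 2 than to compound 1. The measured steps are a 21-fold higher number from compound 1 to compound 2 (1.33 log units; beyond the scatter), an 8.7-fold higher number from compound 1 to compound 3 (0.94 log units; beyond the scatter) and a 2.4-fold lower number from compound 2 to compound 3 (0.39 log units; beyond the scatter), so moving the methoxy group around the ring changes the number well beyond the scatter.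

Compound 4 `Oc1ccccc1-c1cc(-c2ccccc2-c2ccccc2)n[nH]1` has not yet been measured. It differs from compound 3 in one place: 2-hydroxyphenyl in place of 3-methoxyphenyl on an aromatic carbon. The step of a 2.4-fold lower number from compound 2 to compound 3 (0.39 log units; beyond the scatter) bears most directly on this change, since it shows that a 2-methoxyphenyl gives a higher number than a 3-methoxyphenyl, and compound 4 carries a 2-hydroxyphenyl. Among the measured compounds shown here, no measured pair shows the exchange of a methoxy for a hydroxyl, so that part of the change is unknown. Compound 4 is therefore expected to show a 1.7-fold higher number from compound 3 to compound 4 (0.24 log units; within the scatter), landing in the region of the higher numbers seen here. The estimate for compound 4 is 10000 nM, within 3000 nM to 40000 nM.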

Compound 4, concentration for 50% growth inhibition: 5800 nM
Compound 4: the middle estimate sits 1.7-fold (0.24 log units) above what was measured; the range from low to high includes it.
By their numbers in this assay, from the lowest: compound 1; then compounds 3 and 4 (each within the scatter of the next); then compound 2.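

Unmasking the hydroxyl gives the first view of what the group on the oxygen contributes at this position: in this assay, hydrogen in place of methyl accounts for a 2.4-fold lower number from compound 2 to compound 4 (0.39 log units; beyond the scatter), a modest step that the moves of the methoxy group around the ring could not show. The 2-hydroxyphenyl and the 3-methoxyphenyl differ both in where the oxygen sits and in whether it carries a methyl, yet they give no change at the digits printed from compound 3 to compound 4 (within the scatter), so at this level of reading in this assay the two groups cannot be separated. Removing the methyl does not close the gap to the 4-methoxyphenyl, since the comparison with the best compound of the set still shows an 8.7-fold higher number from compound 1 to compound 4 (0.94 log units; beyond the scatter), which leaves compound 1 with the lowest number of the four.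

No measurement among these compounds accounts for any of these steps. As far as these compounds go, what an amine or an ethoxy group would do in place of the hydroxyl of compound 4 remains open, as does whether unmasking the methoxy group of compound 1 would give a step of similar size.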